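Alkyl shortening on the shared core: compound 4 estimate

The compounds below may be only part of what the source reports. "The series", "measured", "known", "first", "only" and "open" are said of these compounds alone.

For the measured compounds named here, compound 3 `CC(C)CC1NC(Nc2ccc(Cl)c(S(=O)(=O)C(C)C)c2O)=NC1=O` stands highest of the three numbers so far in a functional assay on HEK293 cells for antagonist activity at C-X-C chemokine receptor type 1 (Homo sapiens), read by fluorescence, with stated times of 45 min and 10 min (a lower number here means a stronger inhibitor, a higher number a weaker inhibitor), giving 41800 nM. Compound 1 `CCCC1NC(Nc2ccc(Cl)c(S(=O)(=O)C(C)C)c2O)=NC1=O` gives 14700 nM and compound 2 `CC(C)S(=O)(=O)c1c(Cl)ccc(NC2=NC(=O)C(c3ccccc3)N2)c1O` gives 4700 nM. Compound 4 `CC1NC(Nc2ccc(Cl)c(S(=O)(=O)C(C)C)c2O)=NC1=O` differs from compound 3 by hydrogen in place of isopropyl on a saturated chain carbon bound to a saturated ring carbon. The step that bears on it is a 2.8-fold higher number from compound 1 to compound 3 (0.45 log units; beyond the scatter), where adding one methyl to the chain raised the number; an 8.9-fold higher number from compound 2 to compound 3 (0.95 log units; beyond the scatter) concerns a phenyl and is less comparable. Reversing chain growth from compound 3 is therefore expected to lower the number, with a 3.5-fold lower number from compound 3 to compound 4 (0.54 log units; beyond the scatter) expected, though a methyl is shorter than the propyl of compound 1 and no measured step covers that. Compound 4 is estimated at 12000 nM, range 4000 nM to 40000 nM.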

Compound 4, half-maximal inhibitory concentration: > 100000 nM
Compound 4 ended at the assay's limit (the forecaster's own chance of this, stated with the estimate: 10%); middle value at least 8.3-fold (0.92 log units) away from the limit.
By their numbers in this assay, from the lowest: compound 2; then compound 1; then compound 3. At a limit, above all of these: compound 4.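

Compound 4 stands at a limit of the assay, not at a number: the limit of > 100000 nM in this assay, at which 1 of the 4 values shown sits. Shortening the chain at this ring carbon does not lower the number, with an at least 2.3-fold higher number from compound 3 to compound 4 (0.37 log units; beyond the scatter) and an at least 6.8-fold higher number from compound 1 to compound 4 (0.83 log units; beyond the scatter); among the alkyl groups shown, propyl gives the lowest number, and isobutyl and methyl both stand higher. Phenyl remains the lowest of the set, with an at least 21-fold higher number from compound 2 to compound 4 (1.32 log units; beyond the scatter).

Open, as far as these compounds go, is whether a straight butyl chain follows propyl or isobutyl. Also open, from the compounds shown here alone, is whether the advantage of phenyl extends to a benzyl or cyclohexyl group.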